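The source may report more compounds than this note shows. Statements on the series, on what has been measured and on what is new or still open speak of the compounds shown alone.

Measured so far in a physicochemical assay for lipophilicity; a lower number here means a more polar compound, a higher number a more lipophilic compound:
- compound 1 `c1ccc(CC2CCC3(CC2)OOCCCOO3)cc1`: 3.93
- compound 2 `Fc1ccc(CC2CCC3(CC2)OOCCCOO3)cc1`: 4.01
- compound 3 `N#Cc1ccc(CC2CCC3(CC2)OOCCCOO3)cc1`: 3.46

Compound 2 sits at the top of this small set together with compound 1, as the step of a number 0.08 log units higher from compound 1 to compound 2 (within the scatter) shows. Compound 3 stands apart from both. The next compound, compound 4 `CS(=O)(=O)c1ccc(CC2CCC3(CC2)OOCCCOO3)cc1`, keeps the shared core and differs from compound 2 in one place: methylsulfonyl in place of fluoro on an aromatic carbon.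

Among the compounds with values here, no measured compound carries methylsulfonyl, so the cyano steps are the closest guide. These are modest: a number 0.47 log units lower from compound 1 to compound 3 (beyond the scatter) and a number 0.55 log units lower from compound 2 to compound 3 (beyond the scatter). The change to compound 4 brings in hydrogen-bond acceptors and removes none, and it adds more heavy atoms, so a move in the same direction but of larger size is expected in this assay. The expected step is a number 1.41 log units lower from compound 2 to compound 4 (beyond the scatter), well beyond the scatter. For compound 4 the estimated value is 2.6, with an expected range from 2.1 to 3.1.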

Compound 4, partition coefficient: 2.65
Beside the measured number, compound 4's estimate is 0.05 log units below it; the range from low to high includes it.
By their numbers in this assay, from the lowest: compound 4; then compound 3; then compounds 1 and 2 (each within the scatter of the next).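

In this assay, methylsulfonyl on this aromatic carbon gives the largest steps in the set so far (a number 1.36 log units lower from compound 2 to compound 4 (beyond the scatter) and a number 1.28 log units lower from compound 1 to compound 4 (beyond the scatter)), so this one position can shift the number much further than hydrogen, fluoro and cyano had shown. Methylsulfonyl also goes clearly past cyano (a number 0.81 log units lower from compound 3 to compound 4 (beyond the scatter)), which makes compound 4 the lowest of the four compounds, with each of its steps beyond the scatter. Nothing measured here explains the size of these steps.

From the compounds shown here alone, it remains open whether an amine or a carboxylic acid at this position would give a number lower still or a step of similar size. Going by these compounds, it is also open whether methylsulfonyl would give a similar step on another aromatic carbon of the ring.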